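Phenyl in Place of Methyl on Compound 1

The compounds below may be only part of what the source reports. "The series", "measured", "known", "first", "only" and "open" are said of these compounds alone.

Compound 1 `Cc1cc(Cc2ccccc2)c(O)c2ccccc12` has the lowest number of the three measured in an assay on RBL-1 cells with Polyunsaturated fatty acid 5-lipoxygenase (Rattus norvegicus) as the target (on this read-out lower numbers stand for stronger inhibition and higher numbers for weaker inhibition), giving 20 nM. Compound 3 `CC(c1ccccc1)c1ccc2ccccc2c1O` gives 70 nM, and compound 2 `CN(C)c1ccc(Cc2ccc3ccccc3c2O)cc1` gives 140 nM; both sit beyond the scatter above compound 1. Compound 4 `Oc1c(Cc2ccccc2)cc(-c2ccccc2)c2ccccc12` differs from compound 1 by phenyl in place of methyl on an aromatic carbon. Going by the values given here, no measured pair shows this same change, so there is no step to lean on, and the direction is open. The expectation is a modest loss, a step somewhat beyond the scatter rather than a large one. On that basis compound 4 is expected to give 60 nM in this assay, within a range of 20 nM to 180 nM. This estimate amounts to an expected step of a 3.0-fold higher number from compound 1 to compound 4 (0.48 log units; beyond the scatter).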

Compound 4, half-maximal inhibitory concentration: 56 nM
The estimate for compound 4 lay 1.1-fold (0.03 log units) above the measured number, and the stated range covers the measured number.
By their numbers in this assay, from the lowest: compound 1; then compounds 4, 3 and 2 (each within the scatter of the next, the first and the last beyond it).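

Phenyl, with its six carbons and aromatic ring, can stand in place of methyl on this aromatic carbon, para to the hydroxy group, at only a modest cost in this assay: the change gives a 2.8-fold higher number from compound 1 to compound 4 (0.45 log units; beyond the scatter) and leaves inhibition clearly measurable. Going by these compounds alone, the earlier compounds included no pair differing in one place, so this is the first single change that can be read on the core of compound 1. No available evidence accounts for this loss.

The compounds shown leave open how an amine, a carboxylic acid or a longer alkyl chain would read on this carbon. They also leave open whether a plain hydrogen there would give a higher or lower number than methyl.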